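A Smaller Amine on a Shared Sugar Core

This account rests on a few compounds, and the source may have more. Where it says the series, first, only, none or still open, it means among the compounds named here.

In a functional assay on the whole organism (Pleural cavity) with Rattus norvegicus as the target (on this read-out lower numbers stand for an effect already at smaller amounts and higher numbers for an effect only at larger amounts of compound), compound 1 `OC[C@H]1O[C@@H](n2cnc3c(NCc4ccccc4)nccc32)C[C@@H]1O` gives only a limit, > 9 mg/kg. Compound 2 `[N-]=[N+]=Nc1nccc2ncn([C@H]3C[C@H](O)[C@@H](CO)O3)c12` also reaches only a limit, > 9 mg/kg. Compound 1 therefore stands at the limit of > 9 mg/kg in this assay, at which 2 of the 2 values shown sit, with no measured neighbour to rank it against. Compound 3 `CN(C)c1nccc2c1ncn2[C@H]1C[C@H](O)[C@@H](CO)O1` has not yet been measured; it differs from compound 1 in that (dimethylamino in place of benzylamino on an aromatic carbon). Among the compounds with values here, no measured step exists to guide the size of this change. The step that the limit leaves unreadable from compound 1 to compound 3 is expected to stay within the usual scatter. Compound 3 is thus estimated at 12 mg/kg, between 4 mg/kg and 40 mg/kg.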

Compound 3, dose for half-maximal effect: > 9 mg/kg
Compound 3 was reported as a limit; the forecaster's own chance of this, stated with the estimate: 70%; the middle value is on the limit's open side.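

Compound 1 and compound 3 both end at a limit, so no step between them can be read: the limit of > 9 mg/kg in this assay, at which 3 of the 3 values shown sit.

The compounds shown leave open what dose of any of them gives a half-maximal effect in this assay, and whether swapping benzylamino for dimethylamino changes it.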